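The source may hold more compounds than are shown below. What is called first, only, known or untested is meant among the compounds shown, and "the series" means these compounds.

Measured so far in an in vitro ADME assay on microsomes (Rattus norvegicus) for metabolic stability; on this read-out lower numbers stand for a shorter-lived compound and higher numbers for a longer-lived compound:

- compound 1 `CCc1nc(NC(CC)CC)c(OC)nc1-c1ccc(OC(F)F)cc1Cl` gives 0.783 h
- compound 2 `CCc1nc(-c2ccc(OC(F)(F)F)cc2OC)c(OC)nc1NC(CC)CC` gives 0.6 h
- compound 3 `CCOc1ccc(-c2nc(OC)c(NC(CC)CC)nc2C)c(Cl)c1` gives 0.783 h

The three values sit close together. Compound 3 stands level with compound 1 at the digits shown, and these two share the top of this small set. Compound 2 is the furthest from compound 3, but the gap remains within the scatter, so no order can be read among the three.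

The next compound is compound 4 `CCC(CC)Nc1nc(C)c(-c2ccc(OC(F)F)cc2Cl)nc1OC`, which has not yet been measured in this assay. The change is difluoromethyl in place of ethyl on an oxygen on an aromatic ring, that is, ethoxy to difluoromethoxy. Within the data shown here, no two measured compounds differ in one place only, so the data give no direct measure of this change.

Among the measured compounds shown here, the only indirect guide is that compound 1 also carries the difluoromethoxy group and gives 0.783 h, while compound 3, with ethoxy, gives 0.783 h. On that basis, no step beyond the scatter is expected, in either direction. The expected step is a 1.0-fold higher number from compound 3 to compound 4 (0.01 log units; within the scatter).

The estimate for compound 4 is 0.8 h, with an expected range of 0.45 h to 1.4 h.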

Compound 4, half-life: 0.8 h
For compound 4 middle estimate and measured number coincide at the digits printed, and the stated range covers the measured number.
By their numbers in this assay, from the lowest: compounds 2, 1, 3 and 4 (each within the scatter of the next).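

In this assay, the oxygen on the aromatic ring now has its first direct reading: difluoromethyl in place of ethyl at this place gives a 1.0-fold higher number from compound 3 to compound 4 (0.01 log units; within the scatter), so the two groups cannot be told apart here on this core. A second single-place reading comes from hydrogen in place of methyl on a saturated chain carbon bound to an aromatic carbon, which gives a 1.0-fold higher number from compound 1 to compound 4 (0.01 log units; within the scatter), so the ethyl and methyl forms of that chain also cannot be told apart when the oxygen carries difluoromethyl. No measurement at hand bears on why either change stays within the scatter.

Each of these readings rests on one pair alone, so they show nothing about whether the same changes would read alike on a different core or with a different group at the other place. Also open, going by these compounds, is whether the half-life stays this flat with a clearly different group on the oxygen, such as a longer chain like butyl, or with a carboxylic acid or an amine on the saturated chain carbon.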